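Swapping the pyrazole of compound 1 for a fluorophenyl

A few compounds are considered here, and "the series" means these few. Any claim that something is new, unique, unknown or untested is made for them only; others in the source may bear on it.

Compound 1, `COc1ccc(CNC(=O)c2cc(-c3cncc(C)c3)ncc2-c2cnn(C)c2)nc1OC`, is the middle one of three measured compounds in an assay on CHO cells for displacement of a labelled ligand from Orexin receptor type 2 (Homo sapiens), read by scintillation counting, with a stated time of 3 h (a lower number here means a stronger inhibitor, a higher number a weaker inhibitor), where compound 1 gives 4.1 nM. Compound 3, `COc1ccc(CNC(=O)c2nc(-c3cncc(C)c3)cnc2-c2ccccc2)nc1OC`, gives 1.4 nM in this assay, a stronger result, while compound 2, `COc1ccc(CNC(=O)c2nc(-c3cncc(C)c3)ccc2-c2ccccc2)nc1OC`, gives 43 nM, a clearly weaker one. Compound 4, `COc1ccc(CNC(=O)c2cc(-c3cncc(C)c3)ncc2-c2ccccc2F)nc1OC`, keeps the core of compound 1 and changes one group: 2-fluorophenyl in place of 1-methyl-1H-pyrazol-4-yl on an aromatic carbon. Within the data shown here, no measured pair shows exactly this exchange, so its size cannot be read off directly. The account expects a modest step toward a higher number, a 2.4-fold higher number from compound 1 to compound 4 (0.39 log units; beyond the scatter), though one that might still sit within the scatter. Compound 4 is therefore estimated at 10 nM, between 3 nM and 35 nM.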

Compound 4, inhibition constant: 1.4 nM
Compound 4: the middle estimate sits 7.1-fold (0.85 log units) above what was measured; the whole stated range lies above it.
By their numbers in this assay, from the lowest: compounds 3 and 4 (each within the scatter of the next); then compound 1; then compound 2.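

At this position, on an aromatic carbon of the core of compound 1, the 1-methyl-1H-pyrazol-4-yl group is not needed for a low number: in this assay, 2-fluorophenyl in its place gives a 2.9-fold lower number from compound 1 to compound 4 (0.47 log units; beyond the scatter) at this site. The entering group carries no hydrogen-bond acceptors, unlike the group it replaces, yet the number still falls. Nothing measured here accounts for this step.

As far as these compounds go, whether the fluorine contributes stays open. So does whether a morpholine or a carboxylic acid at this position on the same core would keep the number this low.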